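Naphthyloxymethyl oxadiazole semicarbazones in the electroshock model

This account rests on a few compounds, and the source may have more. Where it says the series, first, only, none or still open, it means among the compounds named here.

Measured so far:
compound 1 `O=C(N/N=C\c1ccccc1)Nc1nnc(COc2ccc3ccccc3c2)o1` — 300 mg/kg
compound 2 `O=C(N/N=C\c1ccc(O)cc1)Nc1nnc(COc2ccc3ccccc3c2)o1` — 300 mg/kg
compound 3 `Cc1ccc(/C=N\NC(=O)Nc2nnc(COc3ccc4ccccc4c3)o2)cc1` — 300 mg/kg

In a functional assay on the whole organism (strain Swiss albino) with Mus musculus as the target, in the maximal electroshock model, with a stated time of 4 h (on this read-out lower numbers stand for an effect already at smaller amounts and higher numbers for an effect only at larger amounts of compound), compound 3 gives 300 mg/kg, level with compound 1 and compound 2 at the digits read. Going by the values given here, the series so far carries no step that leaves the scatter: no change at the digits printed from compound 1 to compound 2 (within the scatter), no change at the digits printed from compound 1 to compound 3 (within the scatter), and no change at the digits printed from compound 2 to compound 3 (within the scatter).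

Compound 4 `C/C(=N/NC(=O)Nc1nnc(COc2ccc3ccccc3c2)o1)c1ccc(O)cc1` is not yet measured. Relative to compound 3 the difference is a group of 10 heavy atoms (8 carbon, 1 nitrogen, 1 oxygen; one six-membered aromatic ring of carbon only) in place of a group of 9 heavy atoms (8 carbon, 1 nitrogen; one six-membered aromatic ring of carbon only), on an amide-type nitrogen. Two of the measured steps bear on it. The step of no change at the digits printed from compound 2 to compound 3 (within the scatter) covers the exchange of methyl and hydroxy on the ring, and the step of no change at the digits printed from compound 1 to compound 2 (within the scatter) covers hydroxy entering on the ring; both sit within the scatter. Among the compounds with values here, no measured pair covers the extra carbon on the double bond of the entering group, so that part rests on nothing in this set.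

With all three measured steps flat, the step from compound 3 to compound 4 is expected as no change at the digits printed from compound 3 to compound 4 (within the scatter), that is none beyond the scatter. Compound 4 is therefore estimated at 300 mg/kg, within 150 mg/kg to 600 mg/kg.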

Compound 4, minimum effective dose: 300 mg/kg
Compound 4: middle estimate and measured number agree at the digits printed; measured number inside the range.
By their numbers in this assay, from the lowest: compounds 1, 2, 3 and 4 (each within the scatter of the next).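

In this assay, going by these compounds alone, the pair that isolates the extra carbon on the double bond of the group on the amide-type nitrogen reads no change at the digits printed from compound 2 to compound 4 (within the scatter); this is the one part of the change that no earlier pair covered. The other two new steps read no change at the digits printed from compound 3 to compound 4 (within the scatter) and no change at the digits printed from compound 1 to compound 4 (within the scatter), so at this place the group of 10 heavy atoms stands level with the groups of 8 and 9 heavy atoms. No measured information is at hand to explain this flat result.

With all four compounds level, nothing shown yet identifies a change at this place that leaves the scatter. Open, on these data alone, are an amine or a carboxylic acid on the ring, a longer chain in place of the extra carbon, and any change to the shared core.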